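Series notes: replacing the aryl group on the shared core

The compounds below may be only part of what the source reports. "The series", "measured", "known", "first", "only" and "open" are said of these compounds alone.

Measured so far in a functional assay on HUVEC cells (Homo sapiens) for inhibition, read by ELISA; on this read-out higher numbers stand for weaker inhibition and lower numbers for stronger inhibition:
compound 1 `COc1c(C)cnc(C[S+]([O-])c2nnc(-c3ccccc3)o2)c1C` — 7000 nM
compound 2 `COc1c(C)cnc(C[S+]([O-])c2nnc(-c3ccc(F)cc3)o2)c1C` — 14000 nM
compound 3 `COc1c(C)cnc(C[S+]([O-])c2nnc(-c3cccc(F)c3)o2)c1C` — 15000 nM

Compound 3 carries the highest number of the three. Its nearest neighbour is compound 2, and the step of a 1.1-fold higher number from compound 2 to compound 3 (0.03 log units; within the scatter) lies within the scatter, so the two cannot be ordered. Its furthest neighbour is compound 1, and the step of a 2.1-fold higher number from compound 1 to compound 3 (0.33 log units; beyond the scatter) is beyond the scatter, if only modestly. The parallel step a 2.0-fold higher number from compound 1 to compound 2 (0.30 log units; within the scatter) stays within the scatter. Taken together, adding a fluorine to the phenyl ring, at either position tested, has shifted the number by little.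

Compound 4 `COc1c(C)cnc(C[S+]([O-])c2nnc(-c3cccn3C)o2)c1C` differs from compound 3 by 1-methyl-1H-pyrrol-2-yl in place of 3-fluorophenyl on an aromatic carbon. None of the three measured steps concerns an exchange of one aromatic ring for another; they only move a fluorine on the same phenyl ring. The data thus give no direct guide, and the only lesson is that small changes to this aryl group have produced small steps. On that basis no step beyond the scatter is expected from compound 3 to compound 4, in either direction, with a wide uncertainty to allow for the untested ring exchange. The expected step is a 1.3-fold lower number from compound 3 to compound 4 (0.10 log units; within the scatter). Compound 4 is estimated at 12000 nM, with a range from 4000 nM to 40000 nM.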

Compound 4, half-maximal inhibitory concentration: 6000 nM
Beside the measured number, compound 4's estimate is 2.0-fold (0.30 log units) above it; low and high end bracket the measured number.
By their numbers in this assay, from the lowest: compounds 4, 1, 2 and 3 (each within the scatter of the next, the first and the last beyond it).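

In this assay, exchanging the whole aromatic ring at this position gives steps beyond the scatter, if only modestly, where the fluorinated phenyl rings are the starting point: 1-methyl-1H-pyrrol-2-yl in place of 3-fluorophenyl gives a 2.5-fold lower number from compound 3 to compound 4 (0.40 log units; beyond the scatter), and in place of 4-fluorophenyl it gives a 2.3-fold lower number from compound 2 to compound 4 (0.37 log units; beyond the scatter). Against the unsubstituted phenyl ring, the same exchange gives a 1.2-fold lower number from compound 1 to compound 4 (0.07 log units; within the scatter), which lies within the scatter, so compound 1 and compound 4 cannot be ordered and the position tolerates a five-membered aromatic ring with one hetero atom as well as it does phenyl. Nothing in the material shown bears on what lies behind these steps.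

The compounds shown leave open whether the methyl group on the pyrrole ring matters, which the 1H-pyrrol-2-yl group without it would test, and whether other rings such as thiophene, pyridine or furan would give numbers that can be separated from those of compound 1 and compound 4. Also open, as far as these compounds go, is how an amine or a carboxylic acid on the aromatic ring at this position would shift the number.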